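Aminophenyl analogue on the thienopyridine-type shared core

A few compounds are considered here, and "the series" means these few. Any claim that something is new, unique, unknown or untested is made for them only; others in the source may bear on it.

Measured so far in a functional assay on MCF7 cells (Homo sapiens) for inhibition, read by sulforhodamine B assay, with a stated time of 48 h; a higher number here means a weaker inhibitor of growth, a lower number a stronger inhibitor of growth:
Compound 1 `COC(=O)c1sc2cc(-c3cccnc3)cnc2c1N` gives > 112000 nM, a limit of the assay.
Compound 2 `COC(=O)c1sc2cc(-c3ccc(C(C)=O)cc3)cnc2c1N` gives > 150000 nM, also a limit.
Compound 3 `COC(=O)c1sc2cc(-c3ccc(C(F)(F)F)cc3)cnc2c1N` gives > 150000 nM, again a limit.

Compound 3 thus stands at the upper limit of this assay, as do two of the three values shown; the third sits at a lower limit. Among the measured compounds shown here, the one single-point step between measured compounds, a step that the two limits leave unreadable from compound 2 to compound 3, cannot be read because both ends are limits. For the measured compounds named here, no measured step therefore gives a size or direction.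

Compound 4 `COC(=O)c1sc2cc(-c3ccc(N)cc3)cnc2c1N` differs from compound 3 by amino in place of trifluoromethyl on an aromatic carbon. With no readable step available, and with the limit of > 150000 nM in this assay, at which 2 of the 3 values shown sit, holding two of the three values, the expectation is that compound 4 also reaches no numeric value in this assay. Compound 4 is expected at 150000 nM, with a range from 30000 nM to 600000 nM. The expected step is a number no higher from compound 3 to compound 4 (the limit leaves the size open), that is, none beyond the scatter.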

Compound 4, concentration for 50% growth inhibition: 108000 nM
The estimate for compound 4 lay 1.4-fold (0.14 log units) above the measured number; the range from low to high includes it.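

In this assay compound 4 is the only compound shown with a numeric value rather than a limit, and the amino group on this aromatic carbon gives an at least 1.3-fold lower number from compound 3 to compound 4 (0.14 log units; that floor lies within the scatter), an at least 1.3-fold lower number from compound 2 to compound 4 (0.14 log units; that floor lies within the scatter) and, for the whole aryl group, an at least 1.0-fold lower number from compound 1 to compound 4 (0.01 log units; that floor lies within the scatter). For the first two steps, only a floor can be given because the trifluoromethyl and acetyl compounds both sit at a limit: the limit of > 150000 nM in this assay, at which 2 of the 4 values shown sit. The step from the pyridin-3-yl compound is likewise only a floor because compound 1 also sits at a limit: the limit of > 112000 nM in this assay, at which 1 of the 4 values shown sits.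

On these data alone, whether the true gaps lie beyond the scatter remains open, since all three floors lie within it. Also open, as far as these compounds go, is whether a dimethylamino group or a hydroxyl group at the same place would give a numeric value, and what a carboxylic acid in place of the methyl ester on the shared core would do.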